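Swapping a chlorobenzyl for a naphthylmethyl on sulfur

The source may hold more compounds than are shown below. What is called first, only, known or untested is meant among the compounds shown, and "the series" means these compounds.

Compound 2 `Cc1cc(Nc2cc(-c3ccccc3)[nH]n2)n2nc(SCc3ccc(Cl)cc3)nc2n1` is tested in a functional assay on MCF7 cells (Homo sapiens) for inhibition, read by MTT assay, with a stated time of 72 h (a higher number here means a weaker inhibitor, a lower number a stronger inhibitor), and gives 8260 nM. Among the three measured compounds it carries the highest number, but its gap to the other two lies within the scatter, so no ordering can be read from it. Compound 3 `CCCCCc1c(C)nc2nc(SCc3ccc(Cl)cc3)nn2c1Nc1cc(-c2ccccc2)[nH]n1` gives 6390 nM, and compound 1 `Cc1cc(Nc2ccn(Cc3cccc4ccccc34)n2)n2nc(SCc3ccc(Br)cc3)nc2n1` gives 4310 nM. The one single-point step among these, a 1.3-fold lower number from compound 2 to compound 3 (0.11 log units; within the scatter), shows that adding a pentyl chain to the shared core changes little.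

Compound 4 `Cc1cc(Nc2cc(-c3ccccc3)[nH]n2)n2nc(SCc3cccc4ccccc34)nc2n1` differs from compound 2 only by naphthalen-1-yl in place of 4-chlorophenyl on a saturated chain carbon bound to a sulfur. Within the data shown here, no measured step matches this change directly. Compound 1 also carries a (naphthalen-1-yl)methyl on sulfur but differs from compound 2 in a second place as well, so its value only hints that a naphthalene at this position is tolerated. The expected step is therefore small, a 1.5-fold lower number from compound 2 to compound 4 (0.18 log units; within the scatter), not beyond the scatter. For compound 4 the expected value in this assay is 5500 nM, with a range from 2500 nM to 12000 nM.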

Compound 4, half-maximal inhibitory concentration: 7560 nM
The estimate for compound 4 lay 1.4-fold (0.14 log units) below the measured number; the measured number falls inside the stated range.
By their numbers in this assay, from the lowest: compounds 1, 3, 4 and 2 (each within the scatter of the next).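

Among these compounds, on the saturated chain carbon bound to a sulfur, compound 4 gives the first direct reading of this swap: in this assay, naphthalen-1-yl in place of 4-chlorophenyl gives a 1.1-fold lower number from compound 2 to compound 4 (0.04 log units; within the scatter), a step within the scatter. The entering group has 10 heavy atoms and 2 aromatic rings, against 7 heavy atoms and one ring in the group that leaves, and it has no chlorine, yet this assay shows no readable change. No measurement here explains why the swap leaves the number unchanged.

Every group on this sulfur so far holds an aromatic ring, so a plain butyl chain or a benzyl carrying a carboxylic acid remains an open case. Also open, as far as these compounds go, is whether this swap would read the same with the pentyl chain of compound 3 on the core.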